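The source may hold more compounds than are shown below. What is called first, only, known or untested is meant among the compounds shown, and "the series" means these compounds.

Values measured in a functional assay on PC-3 cells (Homo sapiens) for cytotoxicity, read by WST assay, with a stated time of 72 h; a lower number here means a stronger inhibitor, a higher number a weaker inhibitor:
- compound 1 `O=C1Nc2c(ccc(F)c2F)C1(c1ccccc1)c1ccc(O)cc1` gives 8.9 nM
- compound 2 `Cc1ccc(C2(c3ccc(O)cc3)C(=O)Nc3c2ccc(F)c3F)cc1` gives 0.8 nM
- compound 3 `O=C1Nc2c(ccc(F)c2F)C1(c1ccc(O)cc1)c1ccc(F)c(F)c1` gives 19 nM

Compound 3 has the highest number of the three, which makes it the weakest inhibitor so far. Compound 1 is its nearest neighbour and compound 2 its furthest.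

The next change turns it into compound 4 `O=C1Nc2c(ccc(F)c2F)C1(c1ccc(O)cc1)c1cccs1` and puts thiophen-2-yl in place of 3,4-difluorophenyl on a saturated ring carbon is the full count of what leaves and enters.

All three measured steps concern the aromatic ring at this carbon. The modest one is a 2.1-fold higher number from compound 1 to compound 3 (0.33 log units; beyond the scatter) when phenyl gives way to 3,4-difluorophenyl. Two steps are large: an 11-fold lower number from compound 1 to compound 2 (1.05 log units; beyond the scatter) for a single added methyl, and a 24-fold higher number from compound 2 to compound 3 (1.38 log units; beyond the scatter) for the swap of 4-methylphenyl for 3,4-difluorophenyl. Small edits here can therefore move the number a long way, and no five-membered ring has been measured at this carbon, so the range must stay wide.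

Thiophen-2-yl carries no substituent, and neither does the phenyl ring of compound 1 (8.9 nM), so that compound is the best guide. The expected change is modest and toward a lower number, a 2.4-fold lower number from compound 3 to compound 4 (0.38 log units; beyond the scatter) in this assay, as an estimate only.

Compound 4 is estimated at 8 nM (expected range 2.5 nM to 30 nM).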

Compound 4, half-maximal inhibitory concentration: 0.3 nM
For compound 4 the middle estimate is 27-fold (1.43 log units) above the measured one, outside the stated range (below it).
By their numbers in this assay, from the lowest: compound 4; then compound 2; then compound 1; then compound 3.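

In this assay, thiophen-2-yl is the strongest of the four groups shown on this saturated ring carbon, well ahead of 3,4-difluorophenyl (a 63-fold lower number from compound 3 to compound 4 (1.80 log units; beyond the scatter)) and of plain phenyl (a 30-fold lower number from compound 1 to compound 4 (1.47 log units; beyond the scatter)), and still ahead of 4-methylphenyl by a smaller margin (a 2.7-fold lower number from compound 2 to compound 4 (0.43 log units; beyond the scatter)). Two aromatic rings that both carry no substituent can therefore lie far apart here, so the absence of a substituent says little on its own, and a five-membered ring with one hetero atom can do what the added methyl of compound 2 did and go further. Nothing available on these compounds explains why this ring gives such a low number.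

On these data alone, whether the sulfur atom matters or the smaller ring alone is enough remains open, and furan-2-yl or thiophen-3-yl on the same carbon would be the direct comparisons. As far as these compounds go, it is also open whether a methyl on the thiophen-2-yl ring would lower the number again, as it did on phenyl (an 11-fold lower number from compound 1 to compound 2 (1.05 log units; beyond the scatter)).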